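The source may hold more compounds than are shown below. What is called first, only, known or untested is meant among the compounds shown, and "the series" means these compounds.

Measured set: compound 1 `Cc1ccc(CN2CCN(C(=O)CN[C@H]3CCN(S(=O)(=O)Cc4ccccc4)C3)CC2)cc1` and compound 2 `O=C(CN[C@H]1CCN(S(=O)(=O)Cc2ccccc2)C1)N1CCN(Cc2ccc(Cl)cc2)CC1`. Not yet measured: compound 3 `O=C(CN[C@H]1CCN(S(=O)(=O)Cc2ccccc2)C1)N1CCN(Cc2cccc(C(F)(F)F)c2)CC1`.

In a functional assay on K562 cells (Homo sapiens) for cytotoxicity, read by MTT assay, with a stated time of 48 h (on this read-out lower numbers stand for stronger inhibition and higher numbers for weaker inhibition), compound 1 gives 8200 nM, and compound 2 gives 9200 nM. The two numbers lie within the scatter of each other, so compound 1 is not separated from compound 2 here. The single step shown, a 1.1-fold higher number from compound 1 to compound 2 (0.05 log units; within the scatter), concerns the same place, the saturated chain carbon bound to an amine nitrogen in a ring. Compound 3 differs from compound 1 by 3-(trifluoromethyl)phenyl in place of 4-methylphenyl on a saturated chain carbon bound to an amine nitrogen in a ring. Going by the values given here, no measured step covers a 3-(trifluoromethyl)phenyl group. Among the compounds with values here, on the one small step seen, compound 3 is expected to show a 1.0-fold lower number from compound 1 to compound 3 (0.01 log units; within the scatter), nothing beyond the scatter. The estimated value for compound 3 is 8000 nM, range 3000 nM to 22000 nM.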

Compound 3, half-maximal inhibitory concentration: 3600 nM
The estimate for compound 3 lay 2.2-fold (0.35 log units) above the measured number, and the stated range covers the measured number.
By their numbers in this assay, from the lowest: compound 3; then compounds 1 and 2 (each within the scatter of the next).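

In this assay the aryl group on a saturated chain carbon bound to an amine nitrogen in a ring can shift the number beyond the scatter: 3-(trifluoromethyl)phenyl gives a 2.3-fold lower number from compound 1 to compound 3 (0.36 log units; beyond the scatter) and a 2.6-fold lower number from compound 2 to compound 3 (0.41 log units; beyond the scatter) and both steps are modest. Each step changes the substituent and its printed ring number together, so these two contributions stay unseparated. Nothing available explains the lower number.

Open, going by these compounds, is whether 4-(trifluoromethyl)phenyl or 3-methylphenyl would match compound 3 and so show which part of the change matters. Also open, on these data alone, is how a nitrile, a methoxy group or an amine would read at this place.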